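The compounds below may be only part of what the source reports. "The series", "measured", "known", "first", "only" and "open" are said of these compounds alone.

Working notes on the series. The shared core of compound 1 `O=C(/C=C/c1cccc(O)c1)c1cc(O)c(O)c([N+](=O)[O-])c1` carries an enone chain that ends in a 3-hydroxyphenyl group. In an assay on isolated protein for inhibition of Amine oxidase [flavin-containing] B (Homo sapiens), read by fluorescence (a lower number here means a stronger inhibitor, a higher number a weaker inhibitor), compound 1 gives 55800 nM. Compound 2 `N#Cc1cccc(/C=C/C(=O)c2cc(O)c(O)c([N+](=O)[O-])c2)c1` gives 60600 nM in this assay, and compound 3 `CC(=O)N1N=C(c2cc(O)c(O)c([N+](=O)[O-])c2)CC1c1ccoc1`, built on the same core with a different chain, gives 126000 nM. For the measured compounds named here, compound 1 thus stands at the low end of the three numbers; compound 2 lies within the scatter of it, since the only measured single-point step, a 1.1-fold higher number from compound 1 to compound 2 (0.04 log units; within the scatter), is within the scatter, while compound 3 lies beyond the scatter at the high end.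

Compound 4 `Cn1cc(/C=C/C(=O)c2cc(O)c(O)c([N+](=O)[O-])c2)cn1` is not yet measured. It differs from compound 1 in one place: 1-methyl-1H-pyrazol-4-yl in place of 3-hydroxyphenyl on a double-bonded chain carbon bound to a double-bonded chain carbon. Going by the values given here, no measured step exchanges the whole terminal ring. Among the compounds with values here, the step from compound 1 to compound 2 is the only one touching that ring; it changed a single substituent and stayed within the scatter, which gives limited ground for expecting the terminal ring to tolerate change. The present exchange is larger, swapping a six-membered carbon ring for a five-membered ring with 2 hetero atoms, so a step of about the scatter limit is expected, with the direction unresolved by the data and a higher number taken as the working case. The expected step is a 1.3-fold higher number from compound 1 to compound 4 (0.13 log units; within the scatter). Compound 4 is therefore estimated at 75000 nM in this assay, in a range from 30000 nM to 180000 nM.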

Compound 4, half-maximal inhibitory concentration: 66200 nM
The estimate for compound 4 lay 1.1-fold (0.05 log units) above the measured number; low and high end bracket the measured number.
By their numbers in this assay, from the lowest: compounds 1, 2, 4 and 3 (each within the scatter of the next, the first and the last beyond it).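

The exchange gives a 1.2-fold higher number from compound 1 to compound 4 (0.07 log units; within the scatter) in this assay, so on a double-bonded chain carbon bound to a double-bonded chain carbon the whole 3-hydroxyphenyl group, and not only its hydroxy substituent, can be replaced without a step beyond the scatter. The earlier step touched a single substituent, whereas this one changes the ring size, brings in 2 hetero atoms and removes the carbon-only ring, and it still stays within the scatter. Nothing measured alongside these numbers offers an explanation for this result.

Open, going by these compounds, is whether a carboxylic acid or a dimethylamino group on the terminal ring, or a saturated ring such as piperidine in place of that ring, would give a step beyond the scatter at this place. Also open is how far the number depends on the hydroxy and nitro groups of the shared core, which all the compounds shown carry unchanged, so that a methoxy group in place of a hydroxy group there cannot yet be judged.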